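A few compounds are considered here, and "the series" means these few. Any claim that something is new, unique, unknown or untested is made for them only; others in the source may bear on it.

Measured compounds:
- Compound 1, `CN(C)c1ccc(C(=O)Nc2cccc(NC(=O)COc3ccc4occc(=O)c4c3)c2)cc1`, in an assay on isolated protein for inhibition of Rho-associated protein kinase 2 (Homo sapiens), read by scintillation counting, radiometric assay and 33P incorporation, with a stated time of 40 min, in the presence of a further agent that is not named here (on this read-out higher numbers stand for weaker inhibition and lower numbers for stronger inhibition), gives > 10000 nM.
- Compound 2, `Cn1ccc(S(=O)(=O)Nc2cccc(NC(=O)COc3ccc4c(=O)ccoc4c3)c2)n1`, gives 1350 nM.
- Compound 3, `CC(C)(C)c1ccc(S(=O)(=O)Nc2cccc(NC(=O)COc3ccc4c(=O)ccoc4c3)c2)cc1`, gives 899 nM.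

The value of compound 1 is a limit of the assay rather than a number, as noted in the limit of > 10000 nM in this assay, at which 1 of the 3 values shown sits. Among the two numbers that remain, compound 3 holds the lower one, but the step of a 1.5-fold lower number from compound 2 to compound 3 (0.18 log units; within the scatter) is within the scatter, so the two cannot be told apart on this evidence.

Compound 4, `O=C(COc1ccc2c(=O)ccoc2c1)Nc1cccc(NS(=O)(=O)c2ccc(OC(F)(F)F)cc2)c1`, has not yet been measured. It differs from compound 3 by trifluoromethoxy in place of tert-butyl on an aromatic carbon. Within the data shown here, only one measured step exists, and it changed the whole group on the sulfonyl sulfur rather than a single substituent on the phenyl ring; it was itself within the scatter. Among the measured compounds shown here, no measured step therefore bears directly on this change, and the expectation for compound 4 is a step of a 1.0-fold higher number from compound 3 to compound 4 (0.00 log units; within the scatter) that stays within the scatter. On that basis compound 4 is estimated at 900 nM, with a range from 400 nM to 2000 nM.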

Compound 4, half-maximal inhibitory concentration: 1280 nM
Compound 4: middle estimate off by 1.4-fold (0.15 log units), on the low side, and the stated range covers the measured number.
By their numbers in this assay, from the lowest: compounds 3, 4 and 2 (each within the scatter of the next). At a limit, above all of these: compound 1.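

In this assay there is a 1.4-fold higher number from compound 3 to compound 4 (0.15 log units; within the scatter) when trifluoromethoxy takes the place of tert-butyl, and this is the only step shown that changes just one substituent on the phenyl ring. On this aromatic carbon, para to a large group, two groups with different atoms and different hydrogen-bond acceptor counts therefore cannot be told apart. There is also a 1.1-fold lower number from compound 2 to compound 4 (0.02 log units; within the scatter) when 4-(trifluoromethoxy)phenyl takes the place of 1-methyl-1H-pyrazol-3-yl on the sulfonyl sulfur, so this larger exchange cannot be read as a difference either.

Going by these compounds, whether an amine or a carboxylic acid at this para position would move the number beyond the scatter of compound 3 remains open. Nothing measured here accounts for how close these values lie.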